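Working notes: 2-phenylphenyl on the naphthalen-2-yl compound

The source may report more compounds than this note shows. Statements on the series, on what has been measured and on what is new or still open speak of the compounds shown alone.

Measured so far in a physicochemical assay for lipophilicity; on this read-out higher numbers stand for higher lipophilicity and lower numbers for lower lipophilicity
- compound 1 `C=C(c1cccc2ccccc12)C1CCC2(CC1)COC(Nc1cc(Cl)cc(Cl)c1)OO2` gives 6.71
- compound 2 `C=C(c1cccc2ccccc12)C1CCC2(CC1)COC(Nc1ccccc1-c1ccccc1)OO2` gives 7.26
- compound 3 `C=C(c1ccc2ccccc2c1)C1CCC2(CC1)COC(Nc1cc(Cl)cc(Cl)c1)OO2` gives 6.71

Compound 3 shares the lowest place of the three with compound 1, the two being level at the digits shown, and compound 2 is the furthest from it. Still unmeasured is compound 4 `C=C(c1ccc2ccccc2c1)C1CCC2(CC1)COC(Nc1ccccc1-c1ccccc1)OO2` which carries 2-phenylphenyl in place of 3,5-dichlorophenyl on an amine nitrogen.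

Going by the values given here, two measured steps bear on this change. The same exchange, made with naphthalen-1-yl in the molecule, gives a number 0.55 log units higher from compound 1 to compound 2 (beyond the scatter) and is the direct precedent, a modest one. Naphthalen-2-yl in place of naphthalen-1-yl gives no change at the digits printed from compound 1 to compound 3 (within the scatter) so the naphthalene attachment offers no reason to expect a different size of step here. Among the compounds with values here, no measured pair yet shows the amine exchange with naphthalen-2-yl in the molecule, so the precedent is a single one. A modest upward step is therefore expected in this assay and the estimate is a number 0.55 log units higher from compound 3 to compound 4 (beyond the scatter) on this basis. For compound 4 the expected value is 7.26 with an estimated range from 6.9 to 7.6 in this working note.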

Compound 4, partition coefficient: 7.26
Beside the measured number, compound 4's estimate shows no gap at the digits printed; the measured number falls inside the stated range.
By their numbers in this assay, from the lowest: compounds 1 and 3 (each within the scatter of the next); then compounds 2 and 4 (each within the scatter of the next).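

In this assay, going by these compounds alone, 2-phenylphenyl in place of 3,5-dichlorophenyl on an amine nitrogen gives a number 0.55 log units higher from compound 3 to compound 4 (beyond the scatter) with naphthalen-2-yl in the molecule, so this change is no longer tied to the single naphthalen-1-yl pair, where it gives a number 0.55 log units higher from compound 1 to compound 2 (beyond the scatter) and the printed size is the same. Naphthalen-2-yl in place of naphthalen-1-yl, previously seen only with 3,5-dichlorophenyl, gives no change at the digits printed from compound 2 to compound 4 (within the scatter) with 2-phenylphenyl, so across these four compounds the group on the amine nitrogen separates the values while the naphthalene attachment does not. No evidence at hand accounts for the size of the amine nitrogen step.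

The compounds shown span only two groups on the amine nitrogen, so it remains open whether the step follows the group's size or its chlorine content, and a plain phenyl or a phenyl carrying a carboxylic acid or a dimethylamino group would test this. Also open, as far as these compounds go, is whether the two places remain separable with something other than naphthalene on the double-bonded chain carbon, such as a plain phenyl or a longer chain.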